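Chloro to Methoxy: Expected Tolerance on Vero Cells

The compounds below may be only part of what the source reports. "The series", "measured", "known", "first", "only" and "open" are said of these compounds alone.

Compound 1, `COC(=O)c1cc(-c2cccc(NC(=O)c3ccc(/C=C/C(=O)c4cccc(C(F)(F)F)c4)cc3)c2)on1`: > 20 ug/mL
Compound 2, `COC(=O)c1cc(-c2cccc(NC(=O)c3ccc(/C=C/C(=O)c4cccc(Cl)c4)cc3)c2)on1`: > 2.5 ug/mL
Compound 3, `COC(=O)c1cc(-c2cccc(NC(=O)c3ccc(/C=C/C(=O)c4cccc(OC)c4)cc3)c2)on1`: not yet measured

In an ADME assay on Vero cells (Chlorocebus sabaeus) for cytotoxicity, read by MTT assay, with a stated time of 72 h (a higher number here means that more compound is tolerated, a lower number that less compound is tolerated), compound 1 gives > 20 ug/mL, which is a limit of the assay rather than a number. Compound 2 gives > 2.5 ug/mL in this assay, again only a limit. Going by the values given here, because of the limit of > 2.5 ug/mL in this assay, at which 1 of the 2 values shown sits, and (the limit of > 20 ug/mL in this assay, at which 1 of the 2 values shown sits), the one measured step, a step that the two limits leave unreadable from compound 1 to compound 2, has no readable size, so compound 2 stands only at a limit, with nothing to rank it against.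

Compound 3 differs from compound 2 by methoxy in place of chloro on an aromatic carbon. Among the compounds with values here, the one measured step bearing on this position is unreadable, so no size or direction can be expected for a step that the limit leaves unreadable from compound 2 to compound 3 beyond a guess, and a further limit is the likeliest outcome. Compound 3 is estimated at 20 ug/mL, in the range 5 ug/mL to 60 ug/mL.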

Compound 3, half-maximal cytotoxic concentration: > 100 ug/mL
Compound 3 ended at the assay's limit (the forecaster's own chance of this, stated with the estimate: 70%); middle value at least 5.0-fold (0.69 log units) from the limit.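

In this assay compound 3 gives > 100 ug/mL, which is a limit of the assay and not a number. Going by these compounds alone, compound 1, compound 2 and compound 3 all stand at limits, so no step among them can be read. Going by these compounds, how the three compounds rank remains open.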